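From 2,6-difluorophenyl to 2,6-dichlorophenyl: notes on compound 4

The compounds below may be only part of what the source reports. "The series", "measured", "known", "first", "only" and "open" are said of these compounds alone.

In an ADME assay on MT4 cells (Homo sapiens) for cytotoxicity, read by MTT assay (a lower number here means that less compound is tolerated, a higher number that more compound is tolerated), compound 1 `O=c1cc(Cc2c(F)cccc2F)nc(SCCCc2ccccc2)[nH]1` gives 32000 nM and compound 3 `O=C(CSc1nc(Cc2c(F)cccc2F)cc(=O)[nH]1)c1ccc([N+](=O)[O-])cc1` gives 22000 nM.

Compound 2 `O=C(CSc1nc(Cc2c(F)cccc2F)cc(=O)[nH]1)c1ccccc1` gives > 67000 nM, which is a limit and not a number. This places compound 2 at the limit of > 67000 nM in this assay, at which 1 of the 3 values shown sits.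

Compound 4 `O=C(CSc1nc(Cc2c(Cl)cccc2Cl)cc(=O)[nH]1)c1ccccc1` differs from compound 2 by 2,6-dichlorophenyl in place of 2,6-difluorophenyl on a saturated chain carbon bound to an aromatic carbon. Among the measured compounds shown here, no measured step changes this group. The nearest guides are changes elsewhere, an at least 2.0-fold higher number from compound 1 to compound 2 (0.32 log units; beyond the scatter) and an at least 3.0-fold lower number from compound 2 to compound 3 (0.48 log units; beyond the scatter), both modest at the least and beyond the scatter. A modest move to a lower number is therefore expected, with the step estimated as an at least 1.4-fold lower number from compound 2 to compound 4 (0.17 log units; that floor lies within the scatter). The estimate for compound 4 is 45000 nM, with an expected range of 17000 nM to 110000 nM.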

Compound 4, half-maximal cytotoxic concentration: > 12000 nM
Compound 4: no number, only a limit; the forecaster's own chance of this, stated with the estimate: 40%; the middle value does not contradict the limit.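

Compound 2 and compound 4 are both recorded only as limits in this assay, and the step between them cannot be read. On these data alone, whether 2,6-dichlorophenyl in place of 2,6-difluorophenyl shifts the tolerated concentration, and in which direction, stays open.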